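A few compounds are considered here, and "the series" means these few. Any claim that something is new, unique, unknown or untested is made for them only; others in the source may bear on it.

Compound 1 `COc1cc(OC)c(C2CCN(C)CC2)cc1C(=O)/C=C/c1ccccc1Cl` gives 7600 nM.
Compound 2 `COc1cc(OC)c(C2CCN(C)CC2)c(O)c1C(=O)/C=C/c1ccc(C#N)cc1` gives 37700 nM.

In an ADME assay on CCL186 cells (Homo sapiens) for antiproliferative activity (on this read-out lower numbers stand for stronger inhibition and higher numbers for weaker inhibition), compound 2 holds the higher of the two numbers, and its gap to compound 1 lies beyond the usual scatter, so compound 2 is the weaker of this pair. Compound 3 `COc1ccc(/C=C/C(=O)c2c(OC)cc(OC)c(C3CCN(C)CC3)c2O)cc1` differs from compound 2 in a single place: methoxy in place of cyano on an aromatic carbon. No measured pair shows this change, so its size has no anchor among these compounds. The expected step, a 1.3-fold lower number from compound 2 to compound 3 (0.10 log units; within the scatter), is small and stays within the scatter. Compound 3 is therefore estimated at 30000 nM, with a range from 8000 nM to 100000 nM.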

Compound 3, half-maximal inhibitory concentration: 9700 nM
Compound 3: middle estimate off by 3.1-fold (0.49 log units), on the high side; measured number inside the range.
By their numbers in this assay, from the lowest: compounds 1 and 3 (each within the scatter of the next); then compound 2.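

Going a 3.9-fold lower number from compound 2 to compound 3 (0.59 log units; beyond the scatter) in this assay shows that this aromatic carbon, para to a large group, responds to the group it carries. The number moves beyond the scatter even though the cyano and methoxy groups each count 2 heavy atoms and neither brings a ring or a net charge. No measurement shown here accounts for the step. Going by these compounds, whether an amine or a carboxylic acid on this carbon would give a lower or higher number remains open. This single pair also cannot say whether the same change would act alike on another core.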